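This account rests on a few compounds, and the source may have more. Where it says the series, first, only, none or still open, it means among the compounds named here.

Working notes on the series. The shared core carries a long chain on the double-bonded carbon, and the end of that chain is where the three measured compounds differ. Compound 3 `CCCCCCCCC(O)CCCCCC/C=C1\CC(CO)(COC(=O)C(C)(C)C)OC1=O` gives 8.91 ug/mL in a functional assay on COLO 205 cells (Homo sapiens) for antiproliferative activity (a higher number here means a weaker inhibitor of growth, a lower number a stronger inhibitor of growth), the highest number of the three: compound 1 `COCCCCCCCCCCCCCCC/C=C1\CC(CO)(COC(=O)C(C)(C)C)OC1=O` gives 0.118 ug/mL and compound 2 `COCCCCCCCCCCC/C=C1\CC(CO)(COC(=O)C(C)(C)C)OC1=O` gives 0.541 ug/mL, so compound 3 is the weakest inhibitor of growth here, with a 76-fold higher number from compound 1 to compound 3 (1.88 log units; beyond the scatter) and a 16-fold higher number from compound 2 to compound 3 (1.22 log units; beyond the scatter) both beyond the scatter.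

The step to compound 4 `CC(C)(C)C(=O)OCC1(CO)C/C(=C\CCCCCCCCCCCCCCC=O)C(=O)O1` is 8-formyloctyl in place of 1-hydroxynonyl on a saturated chain carbon, six bonds along the chain from a double-bonded chain carbon. The change sits at the same place where the two large steps above entered the 1-hydroxynonyl, and it takes that group out again, replacing a chain end bearing a hydroxyl with one ending in a formyl group, closer in kind to the methoxy-ended chains of compound 1 and compound 2. Only those two steps bear on it, and both were large. Among the measured compounds shown here, the expectation is therefore a step in this assay that is beyond the scatter, toward lower numbers, though not necessarily recovering all of the way to compound 1, since no measured compound carries a formyl group. The expected step is a 15-fold lower number from compound 3 to compound 4 (1.17 log units; beyond the scatter).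

Compound 4 is estimated at 0.6 ug/mL in this assay, with a range from 0.15 ug/mL to 3 ug/mL.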

Compound 4, concentration for 50% growth inhibition: > 10 ug/mL
Compound 4: no number, only a limit; the forecaster's own chance of this, stated with the estimate: 5%; at least 16-fold (1.22 log units) between middle value and limit.
By their numbers in this assay, from the lowest: compound 1; then compound 2; then compound 3. At a limit, above all of these: compound 4.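

In this assay compound 4 gives no number, only a limit: the limit of > 10 ug/mL in this assay, at which 1 of the 4 values shown sits. The formyl chain end does not restore the low numbers of the methoxy-ended chains, with an at least 18-fold higher number from compound 2 to compound 4 (1.26 log units; beyond the scatter) and an at least 84-fold higher number from compound 1 to compound 4 (1.92 log units; beyond the scatter), both large steps even at their floors. Against the hydroxyl-bearing chain the reading is an at least 1.1-fold higher number from compound 3 to compound 4 (0.05 log units; that floor lies within the scatter), a floor within the scatter that does not separate the two, so 8-formyloctyl in place of 1-hydroxynonyl brings no visible recovery at this place, six bonds along the chain from a double-bonded chain carbon, and among the four compounds shown only the methoxy-ended chains of compound 1 and compound 2 give low numbers, while the chains of compound 3 and compound 4 do not.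

On these data alone, how far compound 4 actually lies from compound 3 stays open, as a limit offers no number to set against a measured value. Also open, as far as these compounds go, is whether a carboxylic acid, an amine or a hydroxyl at the very end of the chain would read like the methoxy end or like the formyl end.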